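The compounds below may be only part of what the source reports. "The series", "measured", "known", "first", "only" and "open" are said of these compounds alone.

Three related amides carry the same hindered phenol, with two tert-butyl groups flanking the hydroxyl, and a benzyl-substituted piperidine at the other end. Compound 1 `CC(C)(C)c1cc(CCC(=O)NC2CCN(Cc3ccccc3)CC2)cc(C(C)(C)C)c1O` has a saturated two-carbon link to the amide; in an assay on isolated protein for inhibition of Amine oxidase [flavin-containing] A (Homo sapiens), read by fluorescence, with stated times of 15 min and 20 min (a higher number here means a weaker inhibitor, a lower number a stronger inhibitor), compound 1 gives 90200 nM. Compound 2 `CC(C)(C)c1cc(/C=C/C(=O)NC2CCN(Cc3ccccc3)CC2)cc(C(C)(C)C)c1O` keeps that link as a double bond, and in this assay compound 2 gives 42500 nM. Compound 3 `Cc1ccccc1CN1CCC(CCNC(=O)/C=C/c2cc(C(C)(C)C)c(O)c(C(C)(C)C)c2)CC1` keeps the double bond, adds a chain between the amide nitrogen and the piperidine, and carries a methyl on the benzyl ring; in this assay compound 3 gives 69300 nM. Compound 3 stands second highest of the three, but its gap to compound 1 and its gap to compound 2 both lie within the usual scatter, so the three cannot be told apart.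

Compound 4 `CC(C)(C)c1cc(/C=C/C(=O)NCCC2CCN(Cc3ccccc3Cl)CC2)cc(C(C)(C)C)c1O` differs from compound 3 by chloro in place of methyl on an aromatic carbon. Within the data shown here, with no measured pair showing this change, the step of a 1.2-fold lower number from compound 3 to compound 4 (0.06 log units; within the scatter) is expected to stay within the scatter, and compound 4 is estimated at 60000 nM, between 25000 nM and 150000 nM.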

Compound 4, half-maximal inhibitory concentration: 72100 nM
Estimate against measurement, compound 4: 1.2-fold (0.08 log units) below; the range from low to high includes it.
By their numbers in this assay, from the lowest: compounds 2, 3, 4 and 1 (each within the scatter of the next, the first and the last beyond it).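

Among these compounds, this is the first pair that differs in one place only, and in this assay the change from 2-methylbenzyl to 2-chlorobenzyl gives a 1.0-fold higher number from compound 3 to compound 4 (0.02 log units; within the scatter) as its step. At this place on the aromatic ring, methyl and chloro therefore cannot be told apart, and the swap neither helps nor harms inhibition by any amount this assay can resolve. No measurement here offers an explanation for this result.

The compounds shown leave open whether a different kind of group at this place, such as a methoxy, an amine or a carboxylic acid, would move the number beyond the scatter. They also leave open whether the same swap would read alike on a compound without the added chain, such as compound 2.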